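Ester variation in the series: compounds 1 to 3

The source may report more compounds than this note shows. Statements on the series, on what has been measured and on what is new or still open speak of the compounds shown alone.

Measured so far:
- compound 1 `COc1ccc(C(=O)OC2(C(=O)Nc3ccc([N+](=O)[O-])cc3)CCCCC2)cc1`: 41.2 nM
- compound 2 `O=C(OC1(C(=O)Nc2ccc([N+](=O)[O-])cc2)CCCCC1)c1ccc(Br)cc1`: 237 nM

Both numbers come from a functional assay on MCF7 cells (Homo sapiens) for inhibition, read by MTT assay, with a stated time of 72 h; on this read-out lower numbers stand for stronger inhibition and higher numbers for weaker inhibition. Within the data shown here, compound 2 stands at the higher of the two numbers measured in this assay; its only neighbour is compound 1, and the step of a 5.8-fold higher number from compound 1 to compound 2 (0.76 log units; beyond the scatter) sets it apart beyond the scatter.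

The next compound, compound 3 `O=COC1(C(=O)Nc2ccc([N+](=O)[O-])cc2)CCCCC1`, differs from compound 2 by hydrogen in place of 4-bromophenyl on a carbonyl carbon. Among the measured compounds shown here, no measured step bears on this change directly: the single step available, a 5.8-fold higher number from compound 1 to compound 2 (0.76 log units; beyond the scatter), exchanges one substituent on the aromatic ring for another, whereas the step to compound 3 removes that ring from the ester altogether. The precedent therefore gives only a sense of scale, a modest step for a change at the edge of the ester; removing the 4-bromophenyl is a larger change, and the expected step of a 6.3-fold higher number from compound 2 to compound 3 (0.80 log units; beyond the scatter) is taken to exceed the measured one, most likely towards a higher number, with wide uncertainty. For compound 3 in this assay the estimate is 1500 nM, within a range of 200 nM to 10000 nM.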

Compound 3, half-maximal inhibitory concentration: 35.4 nM
For compound 3 the middle estimate is 42-fold (1.63 log units) above the measured one; the whole stated range lies above it.
By their numbers in this assay, from the lowest: compounds 3 and 1 (each within the scatter of the next); then compound 2.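

In this assay, taking the whole aryl group off the ester carbonyl does not weaken the series: hydrogen in place of 4-bromophenyl gives a 6.7-fold lower number from compound 2 to compound 3 (0.83 log units; beyond the scatter) and lies beyond the scatter, while hydrogen in place of 4-methoxyphenyl gives a 1.2-fold lower number from compound 1 to compound 3 (0.07 log units; within the scatter) and lies within it. The aromatic ring on the ester is therefore not needed for a number in the range of compound 1, and among these three compounds only the 4-bromophenyl ester of compound 2 stands apart, with the 4-methoxyphenyl and formyl esters not separable from each other. Nothing available bears on why this position tolerates the loss of the ring.

Still open, going by these compounds, is whether the 4-methoxyphenyl and formyl esters sit level by coincidence, or whether an unsubstituted phenyl, a methyl or a longer chain on the same carbonyl carbon would also fall with them or with compound 2. Also open, on these data alone, is whether an amine in place of the ester oxygen, giving a urea-type link to the shared core, would keep the numbers of compound 1 and compound 3.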